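Trimethoxyphenyl oxadiazolines: swapping the aryl group

A few compounds are considered here, and "the series" means these few. Any claim that something is new, unique, unknown or untested is made for them only; others in the source may bear on it.

Measured compounds:
compound 1 `COc1cc(C2=NN(C(C)=O)C(c3ccc(F)c(F)c3)O2)cc(OC)c1OC`, 18.3%
compound 2 `COc1cc(C2=NN(C(C)=O)C(c3c(Cl)cccc3Cl)O2)cc(OC)c1OC`, -1.4%
compound 3 `COc1cc(C(=O)N/N=C/c2ccc(Cl)c(Cl)c2)cc(OC)c1OC`, 29.6%

Compound 1 `COc1cc(C2=NN(C(C)=O)C(c3ccc(F)c(F)c3)O2)cc(OC)c1OC` carries a 3,4-difluorophenyl on a saturated ring carbon of its five-membered core; in a functional assay on BGC-823 cells (Homo sapiens) for antiproliferative activity, read by MTT assay, tested at 1 uM (on this read-out higher numbers stand for a stronger effect at the one concentration tested and lower numbers for a weaker effect), compound 1 gives 18.3%. Compound 2 `COc1cc(C2=NN(C(C)=O)C(c3c(Cl)cccc3Cl)O2)cc(OC)c1OC` has 2,6-dichlorophenyl at that place, and in this assay compound 2 gives -1.4%, the lowest of the three numbers. Compound 3 `COc1cc(C(=O)N/N=C/c2ccc(Cl)c(Cl)c2)cc(OC)c1OC` has an open-chain hydrazone instead of the ring, and in this assay compound 3 gives 29.6%.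

For the measured compounds named here, the one measured step at the aryl position is a number 19.7 percentage points lower from compound 1 to compound 2 (beyond the scatter). Compound 4 `COc1cc(C2=NN(C(C)=O)C(c3ccc(C(F)(F)F)cc3)O2)cc(OC)c1OC` continues from compound 2 with the change (4-(trifluoromethyl)phenyl in place of 2,6-dichlorophenyl on a saturated ring carbon).

This step runs in the opposite sense to the measured one: the 2,6-dichlorophenyl leaves, and a singly substituted ring enters, closer in pattern to the 3,4-difluorophenyl of compound 1. Going by the values given here, because compound 1 gives 18.3%, a recovery toward that level is the natural expectation, of the order of a number 19.7 percentage points lower from compound 1 to compound 2 (beyond the scatter) reversed, though no measured step covers a trifluoromethyl group directly, so the range is wide.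

Compound 4 is expected to show a number 16.4 percentage points higher from compound 2 to compound 4 (beyond the scatter), landing near 15%, between 0% and 30%.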

Compound 4, a percentage reported as inhibition, at one concentration (the size of the read-out at that concentration, not a potency): 4.2%
Compound 4: the middle estimate sits 10.8 percentage points above what was measured; measured number inside the range.
By their numbers in this assay, from the lowest: compounds 2 and 4 (each within the scatter of the next); then compound 1; then compound 3.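

The swap of 2,6-dichlorophenyl for 4-(trifluoromethyl)phenyl at this saturated ring carbon comes to a number 5.6 percentage points higher from compound 2 to compound 4 (within the scatter) in this assay, so this read-out does not separate these two aryl groups, even though their substitution patterns differ. The comparison with the 3,4-difluorophenyl group turns out differently, with a number 14.1 percentage points lower from compound 1 to compound 4 (beyond the scatter), which means that compound 1 now stands apart from two differently substituted rings rather than from just one, and moving away from the 2,6-dichlorophenyl pattern does not by itself bring the number back to the level of compound 1. No measurement available here accounts for why the 3,4-difluorophenyl group stands apart from the other two.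

Still open, from the compounds shown here alone, is what this position would do with a hydroxyl or dimethylamino group on the phenyl ring, or with a pyridine ring in place of the phenyl ring. Also open, going by these compounds, is whether the same aryl groups would fall in the same order on the open-chain hydrazone of compound 3, which carries a 3,4-dichlorophenyl group, and whether that order would hold at other concentrations.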